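The compounds below may be only part of what the source reports. "The series", "measured", "known", "first", "only" and "open" are said of these compounds alone.

Measured so far in a functional assay on NCI-H630 cells (Homo sapiens) for cytotoxicity, read by sulforhodamine B assay, with a stated time of 5 days; on this read-out lower numbers stand for stronger inhibition and higher numbers for weaker inhibition:
- compound 2, `O=C(CCCCCCCCCCc1ccccc1)CC(=O)N[C@H]1CCOC1=O`: 14000 nM
- compound 3, `O=C(CCCCCCCc1ccccc1)CC(=O)N[C@H]1CCOC1=O`: 10000 nM
- compound 1, `O=C(CCCc1ccccc1)N[C@H]1CCOC1=O`: > 100000 nM, a limit of the assay rather than a number

Compound 1 stands at the limit of > 100000 nM in this assay, at which 1 of the 3 values shown sits, so it offers no number to compare. Among the two numbers that were obtained, compound 2 has the higher one, but its nearest neighbour is compound 3, and the gap between them is a 1.4-fold lower number from compound 2 to compound 3 (0.15 log units; within the scatter). The two compounds therefore cannot be ranked against each other.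

Compound 4, `O=C(CCCCCCCCCCCc1ccccc1)CC(=O)N[C@H]1CCOC1=O`, has not yet been measured. It differs from compound 2 in one place: benzyl in place of phenyl on a saturated chain carbon, ten or more bonds along the chain from a carbonyl carbon. Going by the values given here, the only measured step that speaks to this kind of change is the one from compound 2 to compound 3, where the chain between the carbonyl and the aromatic ring was shortened, and that step was a 1.4-fold lower number from compound 2 to compound 3 (0.15 log units; within the scatter). Lengthening the chain by one carbon in the opposite direction is a smaller alteration of the same kind, so no step beyond the scatter is expected in this assay, in either direction. Compound 4 is accordingly estimated at 14000 nM, with a range from 6000 nM to 33000 nM. That estimate corresponds to an expected step of no change at the digits printed from compound 2 to compound 4 (within the scatter).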

Compound 4, half-maximal inhibitory concentration: 27000 nM
For compound 4 the middle estimate is 1.9-fold (0.29 log units) below the measured one, and the stated range covers the measured number.
By their numbers in this assay, from the lowest: compounds 3, 2 and 4 (each within the scatter of the next, the first and the last beyond it). At a limit, above all of these: compound 1.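

In this assay, benzyl in place of phenyl on a saturated chain carbon, ten or more bonds along the chain from a carbonyl carbon, gives a 1.9-fold higher number from compound 2 to compound 4 (0.29 log units; within the scatter), so this change at this position leaves no readable shift. Going by these compounds alone, what the new number adds is the first gap beyond the scatter among the compounds with numbers: compound 3 at 10000 nM and compound 4 at 27000 nM lie further apart than the scatter, although each stands within the scatter of compound 2, so changes that cannot be read one at a time can still leave a readable gap between the two ends of this short series. Nothing measured here explains the numbers of these chains.

From the compounds shown here alone, whether a still longer chain, or an amine or a carboxylic acid in place of phenyl, would move the number beyond the scatter remains open. Compound 1 is held at a limit of the assay, > 100000 nM, and it differs from the others in more than one place, so what sets it apart cannot be assigned to any single change.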